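The source may report more compounds than this note shows. Statements on the series, on what has been measured and on what is new or still open speak of the compounds shown alone.

Three compounds have been measured so far:

Compound 1, `COc1cc(C(=O)N/N=C/c2ccccc2C(F)(F)F)cc(OC)c1OC`: 35.6%
Compound 2, `COc1cc(C2=NN(C(C)=O)C(c3ccc(F)cc3)O2)cc(OC)c1OC`: 13.3%
Compound 3, `COc1cc(C(=O)N/N=C/c2cc(Cl)cc(Cl)c2)cc(OC)c1OC`: 9.2%

All three share the same trimethoxyphenyl core and were tested in a functional assay on BGC-823 cells (Homo sapiens) for antiproliferative activity, read by MTT assay, tested at 5 uM; a higher number here means a stronger effect of the compound at the concentration tested, a lower number a weaker effect. Within this small set, compound 2 holds the second highest number of the three. Its nearest neighbour is compound 3, whose number lies within the usual scatter of compound 2, so the two cannot be told apart. Compound 1 stands furthest away, with a number that is higher by more than the scatter. Within the data shown here, no pair among the measured compounds differs in a single place, so there is no measured step to lean on for what a single change does here.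

The next compound, compound 4, `COc1cc(C2=NN(C(C)=O)C(c3ccc(F)c(F)c3)O2)cc(OC)c1OC`, differs from compound 2 by fluoro in place of hydrogen on an aromatic carbon. Adding one small fluoro group next to one already present is a modest change, and with no measured single-place step to guide the expectation, the step from compound 2 to compound 4 in this assay is expected to be small, of the size a number 2.7 percentage points higher from compound 2 to compound 4 (within the scatter), and most likely within the scatter in either direction. Compound 4 is therefore expected to give roughly 16% in this assay, with a likely range from 5% to 32%.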

Compound 4, a percentage reported as inhibition, at one concentration (the size of the read-out at that concentration, not a potency): 21.6%
Compound 4: middle estimate off by 5.6 percentage points, on the low side; measured number inside the range.
By their numbers in this assay, from the lowest: compounds 3, 2 and 4 (each within the scatter of the next, the first and the last beyond it); then compound 1.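

In this assay, among these compounds, replacing 4-fluorophenyl with 3,4-difluorophenyl gives a number 8.3 percentage points higher from compound 2 to compound 4 (within the scatter), the first step in this set that isolates one change. It shows that placing fluoro in place of hydrogen on this aromatic carbon, ortho to a fluoro group and meta to a large group, does not separate compound 4 from compound 2 in this read-out, so the two cannot be told apart at the concentration tested. Nothing available here explains this result.

A single small atom is the only replacement shown at this place, so it remains open whether a larger or quite different group, such as an amine or a carboxylic acid, would produce a step beyond the usual scatter. Going by these compounds, it is also open whether the same fluoro change would behave similarly on another scaffold, such as the core of compound 1, since this one step comes from a single pair of compounds.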